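Removing the amine-bearing amide chain of compound 3

A few compounds are considered here, and "the series" means these few. Any claim that something is new, unique, unknown or untested is made for them only; others in the source may bear on it.

Compound 3 `CCN(CC)CCNC(=O)c1ccc(C(CC)(CC)c2ccc(OCC(O)C(C)(C)C)c(C)c2)n1CC` gives 110 nM in an assay on HL-60 cells for agonist activity at vitamin D3 receptor (Homo sapiens), read by microscopy, with a stated time of 96 h (a lower number here means that less compound is needed, a higher number that more compound is needed for the effect), the highest of the two numbers shown; compound 2 `CCN(CC)CCNC(=O)c1ccc(C(CC)(CC)c2ccc(OCC(=O)C(C)(C)C)c(C)c2)n1CC` is nearest at 91 nM, and the step of a 1.2-fold higher number from compound 2 to compound 3 (0.08 log units; within the scatter) lies within the scatter. Compound 1 `CCOC(=O)CN(C)C(=O)c1ccc(C(CC)(CC)c2ccc(OCC(=O)C(C)(C)C)c(C)c2)n1CC` returns only a limit in this assay, > 50000 nM. Compound 4 `C=CCN(C)C(=O)c1ccc(C(CC)(CC)c2ccc(OCC(O)C(C)(C)C)c(C)c2)n1CC` differs from compound 3 by allyl(methyl)amino in place of (2-(diethylamino)ethyl)amino on a carbonyl carbon. For the measured compounds named here, the one measured step that bears on the amide substituent is an at least 540-fold lower number from compound 1 to compound 2 (2.73 log units; beyond the scatter), in which the (2-(diethylamino)ethyl)amino group entered at the same carbonyl carbon; compound 4 again lacks that group, so a large rise in this assay is expected, possibly reaching the limit (the limit of > 50000 nM in this assay, at which 1 of the 3 values shown sits). Compound 4 is therefore estimated at 20000 nM, between 2000 nM and 60000 nM. This expectation means a 180-fold higher number from compound 3 to compound 4 (2.26 log units; beyond the scatter).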

Compound 4, half-maximal effective concentration: 3950 nM
Compound 4: the middle estimate sits 5.1-fold (0.70 log units) above what was measured; the measured number falls inside the stated range.
By their numbers in this assay, from the lowest: compounds 2 and 3 (each within the scatter of the next); then compound 4. At a limit, above all of these: compound 1.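

With the 1-hydroxy-2,2-dimethylpropyl group held fixed, allyl(methyl)amino in place of (2-(diethylamino)ethyl)amino gives a 36-fold higher number from compound 3 to compound 4 (1.56 log units; beyond the scatter) in this assay and so shows that the substituent on this carbonyl carbon also governs the number among compounds carrying the hydroxyl group, not only those carrying the (tert-butyl)carbonyl group. Compound 1 remains the only compound at a limit: the limit of > 50000 nM in this assay, at which 1 of the 4 values shown sits.

The compounds shown leave open whether the rise follows the loss of the diethylamino nitrogen, the amide hydrogen or the chain, as this exchange changes all three together. A 2-(dimethylamino)ethylamino group or a tertiary amide retaining the diethylaminoethyl chain would begin to separate them.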